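Fluoro to hydroxy on the aniline ring of compound 2

This account rests on a few compounds, and the source may have more. Where it says the series, first, only, none or still open, it means among the compounds named here.

Compound 2 `CN(C)C(=O)c1cc2cnc(Nc3ccc(C(=O)NCCCN=C=S)cc3F)nc2n1C1CCCC1` stands lowest of the two numbers measured in a functional assay on NCI-H1299 cells (Homo sapiens) for inhibition, read by CCK-8 assay, with a stated time of 72 h, tested at 1 uM (on this read-out higher numbers stand for a stronger effect at the one concentration tested and lower numbers for a weaker effect), where compound 2 gives 9.27%. Within the data shown here, its nearest neighbour, compound 1 `CN(C)C(=O)c1cc2cnc(Nc3ccc(C(=O)NCCCN=C=S)cc3)nc2n1C1CCCC1`, in this assay gives 65.1%, and the single measured step, a number 55.8 percentage points lower from compound 1 to compound 2 (beyond the scatter), is beyond the scatter. Compound 3 `CN(C)C(=O)c1cc2cnc(Nc3ccc(C(=O)NCCCN=C=S)cc3O)nc2n1C1CCCC1` differs from compound 2 by hydroxy in place of fluoro on an aromatic carbon. Among the measured compounds shown here, no measured step shows a hydroxy group at this position; the only step that bears on it is the one from compound 1 to compound 2, which shows that occupying this aromatic carbon changed the number by a large amount. A hydroxy group may behave differently from fluoro there, so the step is expected to be modest and uncertain in direction, leaning upward: compound 3 is expected to give 25%, within 5% to 60%, an expected step of a number 15.7 percentage points higher from compound 2 to compound 3 (beyond the scatter) from compound 2.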

Compound 3, a percentage reported as inhibition, at one concentration (the size of the read-out at that concentration, not a potency): 10.3%
Beside the measured number, compound 3's estimate is 14.7 percentage points above it, within the range that was stated.
By their numbers in this assay, from the lowest: compounds 2 and 3 (each within the scatter of the next); then compound 1.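

In this assay hydroxy in place of fluoro gives a number 1 percentage points higher from compound 2 to compound 3 (within the scatter) and so the two groups cannot be told apart at this aromatic carbon. Hydroxy in place of hydrogen gives a number 54.8 percentage points lower from compound 1 to compound 3 (beyond the scatter) and this shows that the large drop first seen with fluoro is not peculiar to fluoro: it appears with both groups, the one without a hydrogen-bond donor and the one with a hydrogen-bond donor. No measured property of these groups is at hand to account for this result.

From the compounds shown here alone, whether an amine, a methoxy group or a methyl group on this aromatic carbon would stay level with compound 2 and compound 3 or come back towards compound 1 remains open. Also open, going by these compounds, is whether a longer chain on the amide would change the size of the drop.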